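The compounds below may be only part of what the source reports. "The series", "measured", "known", "first", "only" and "open" are said of these compounds alone.

Measured so far:
compound 1, `CN(c1ncco1)c1cnc(NCc2c(F)ccc3c2CCO3)n2cnnc12`: 11 mL.min-1.g-1
compound 2, `Cc1nccn1-c1cnc(NCc2c(F)ccc3c2CCO3)c2cn[nH]c(=O)c12`: 8 mL.min-1.g-1

In an ADME assay on microsomes from liver (Homo sapiens) for metabolic stability, read by LC-MS, using NADPH, with stated times of 5 min and 30 min, tested at 1 uM (on this read-out higher numbers stand for fast clearance and lower numbers for slow clearance), compound 1 gives 11 mL.min-1.g-1 and compound 2 gives 8 mL.min-1.g-1; the gap between them lies within the usual scatter, so the two cannot be told apart on this read-out. Compound 3, `CNC(=O)c1cc(-c2cnc(NCc3c(F)ccc4c3CCO4)c3cn[nH]c(=O)c23)n(C)n1`, has not yet been measured. It differs from compound 2 in one place: 1-methyl-3-(methylcarbamoyl)-1H-pyrazol-5-yl in place of 2-methyl-1H-imidazol-1-yl on an aromatic carbon. Among the measured compounds shown here, no measured pair shows this kind of change, so there is no basis for expecting a step beyond the scatter in either direction. The step from compound 2 to compound 3 is therefore estimated as no change at the digits printed from compound 2 to compound 3 (within the scatter). Compound 3 is expected to give about 8 mL.min-1.g-1, within a range of 4 mL.min-1.g-1 to 18 mL.min-1.g-1.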

Compound 3, intrinsic clearance in microsomes: < 3 mL.min-1.g-1
Compound 3 ended at the assay's limit; the forecaster's own chance of this, stated with the estimate: 5%; middle value at least 2.6-fold (0.42 log units) from the limit.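

In this assay, among the compounds shown here, the group on this aromatic carbon proves able to move clearance, something no earlier pair could show: 1-methyl-3-(methylcarbamoyl)-1H-pyrazol-5-yl in place of 2-methyl-1H-imidazol-1-yl gives an at least 2.6-fold lower number from compound 2 to compound 3 (0.42 log units; beyond the scatter). Compound 3 gives < 3 mL.min-1.g-1, which is a limit of the assay and not a number, so the step has a minimum but no known full size.

Still open, as far as these compounds go, is whether the methylcarbamoyl or the rest of the new group carries this step. Also open, from the compounds shown here alone, is whether a carboxylic acid or a primary amine in place of the methylcarbamoyl would keep clearance this slow.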